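A few compounds are considered here, and "the series" means these few. Any claim that something is new, unique, unknown or untested is made for them only; others in the source may bear on it.

Series notes in a functional assay on the whole organism (strain albino) for inhibition, with Rattus norvegicus as the target, read by paw edema, with a stated time of 120 min, at a dose of 100 mg/kg by the oral route; a higher number here means more inhibition at the dose given (going by the name of the read-out), a lower number less inhibition:
- compound 1 `Cc1ccc(NCc2nc3ccc(Br)cc3[nH]2)cc1` gives 23.5%
- compound 2 `Clc1cccc(NCc2nc3ccccc3[nH]2)c1` gives 41.1%
- compound 3 `O=[N+]([O-])c1ccc2nc(CNc3ccc(Br)cc3)[nH]c2c1` gives 23.5%

In this assay compound 1 stands level with compound 3 at the digits shown, and these two together hold the lowest of the three numbers; between them there is no change beyond the scatter. Compound 2 sits higher than compound 1, a gap beyond the scatter. For the measured compounds named here, no pair of measured compounds differs in one place only, so no measured step is at hand to lean on.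

Compound 4 `Brc1ccc2nc(CNc3ccccc3)[nH]c2c1` is not yet measured in this assay. It differs from compound 1 as follows: hydrogen in place of methyl on an aromatic carbon. Going by the values given here, with only one carbon leaving and no measured step to guide it, the expected step is a number 2.5 percentage points higher from compound 1 to compound 4 (within the scatter), no larger than the scatter and without a clear direction. Compound 4 is estimated at 26%, with a range from 14% to 40%.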

Compound 4, a percentage reported as inhibition, in the whole organism at one dose (the size of the read-out at that dose, not a potency): 29.4%
The estimate for compound 4 lay 3.4 percentage points below the measured number, within the range that was stated.
By their numbers in this assay, from the lowest: compounds 1, 3 and 4 (each within the scatter of the next); then compound 2.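

In this assay the series gains its first pair differing in one place, with a number 5.9 percentage points higher from compound 1 to compound 4 (within the scatter) when hydrogen replaces methyl on the aromatic carbon para to a large group. At this position, in this pair, the methyl is therefore not required for the inhibition seen at this dose. No evidence on the reason for so small a step is at hand.

Going by these compounds, whether a longer chain, an amine or a carboxylic acid at this position would move the number beyond the scatter stays open. On these data alone, whether the step holds elsewhere also stays open, since it rests on this single pair.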